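A few compounds are considered here, and "the series" means these few. Any claim that something is new, unique, unknown or untested is made for them only; others in the source may bear on it.

Compound 1 `N#CC1=C(N)Oc2c(c3nc4ccccc4nc3c3ccccc23)C12C(=O)N(Cc1cnnn1-c1cccc(Cl)c1)c1ccccc12`: in a functional assay on HCT-116 cells (Homo sapiens) for antiproliferative activity, read by MTT assay, with a stated time of 48 h (a lower number here means a stronger inhibitor, a higher number a weaker inhibitor), compound 1 gives only a limit of the assay, > 50000 nM.
Compound 2 `Cc1ccc(Cl)cc1-n1nncc1CN1C(=O)C2(C(C#N)=C(N)Oc3c2c2nc4ccccc4nc2c2ccccc32)c2ccccc21`: in this assay compound 2 likewise gives only a limit, > 50000 nM.
Compound 3 `CCc1ccccc1-n1nncc1CN1C(=O)C2(C(C#N)=C(N)Oc3c(N)cc4nc5ccccc5nc4c32)c2ccccc21`: in this assay compound 3 gives 10300 nM.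

Among these three, compound 3 stands as the only one with an actual number; the two further values are limits. Going by the values given here, the single measured step between close neighbours, a step that the two limits leave unreadable from compound 1 to compound 2, cannot be sized, since both of its ends sit at the limit of > 50000 nM in this assay, at which 2 of the 3 values shown sit. It therefore tells nothing about how much a change at that position shifts activity.

Compound 4 `Cc1ccc(-n2nncc2CN2C(=O)C3(C(C#N)=C(N)Oc4c(N)cc5nc6ccccc6nc5c43)c3ccccc32)cc1C` differs from compound 3 by 3,4-dimethylphenyl in place of 2-ethylphenyl on an aromatic nitrogen. Among the compounds with values here, no measured step bears on this exchange of one aryl group for another on the aromatic nitrogen: the only recorded step is unreadable and concerns compounds 1 and 2, whose core is not that of compound 3. With nothing to indicate a shift in either direction, the expected step of a 1.0-fold lower number from compound 3 to compound 4 (0.01 log units; within the scatter) is one that stays within the usual scatter. Compound 4 is accordingly estimated to give 10000 nM in this assay, with a range from 3000 nM to 35000 nM that allows for the sparse evidence.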

Compound 4, half-maximal inhibitory concentration: > 50000 nM
Compound 4 was reported as a limit; the forecaster's own chance of this, stated with the estimate: 20%; middle value at least 5.0-fold (0.69 log units) from the limit.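

In this assay, going by these compounds alone, the aryl group on the aromatic nitrogen proves to matter: the exchange gives an at least 4.8-fold higher number from compound 3 to compound 4 (0.68 log units; beyond the scatter), the first step that can be sized, since the earlier step between compound 1 and compound 2 cannot be read. The leaving and entering groups have the same atoms, joined differently, so the step separates 2-ethylphenyl from 3,4-dimethylphenyl by the arrangement of carbon on the phenyl ring alone, with the rest of the structure unchanged. Compound 4 gives only a limit, so the printed size of the step is a floor, and activity at this position is not retained across these two aryl groups: the limit of > 50000 nM in this assay, at which 3 of the 4 values shown sit.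

The compounds shown leave open which feature of the aryl group carries the difference, as a 2-methylphenyl, a 2-propylphenyl or a 3-methylphenyl on the same nitrogen would each separate the substituent's length from its place on the ring. They also leave open how groups with heteroatoms, such as a 2-methoxyphenyl or a 4-aminophenyl, would read in this assay on this core.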